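Joining an Amino Group and a Pyridine at One Position

The source may report more compounds than this note shows. Statements on the series, on what has been measured and on what is new or still open speak of the compounds shown alone.

Measured compounds:
Compound 1, `Cc1ccccc1-c1cc(F)cc(-n2nnc(-c3ccccn3)n2)c1`: 120 nM
Compound 2, `Nc1ccccc1-c1cc(F)cc(-n2nnc(-c3ccccn3)n2)c1`: 8 nM
Compound 3, `Cc1cnccc1-c1cc(F)cc(-n2nnc(-c3ccccn3)n2)c1`: 63 nM

All three were tested in a functional assay for antagonist activity at metabotropic glutamate receptor 5 (Rattus norvegicus) (a higher number here means a weaker inhibitor, a lower number a stronger inhibitor), and share one core, differing only in the group on one aromatic carbon. Compound 1 gives the highest of the three numbers. Compound 3 lies nearest to it, with a 1.9-fold lower number from compound 1 to compound 3 (0.28 log units; within the scatter), and compound 2 furthest, with a 15-fold lower number from compound 1 to compound 2 (1.18 log units; beyond the scatter).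

Compound 4, `Nc1ccncc1-c1cc(F)cc(-n2nnc(-c3ccccn3)n2)c1`, has not yet been measured. Its change from compound 1 is 4-aminopyridin-3-yl in place of 2-methylphenyl on an aromatic carbon. This single change brings together the two changes already measured. One is the step of a 15-fold lower number from compound 1 to compound 2 (1.18 log units; beyond the scatter), where amino replaces methyl; it is large and beyond the scatter. The other is the step of a 1.9-fold lower number from compound 1 to compound 3 (0.28 log units; within the scatter), where 3-methylpyridin-4-yl replaces 2-methylphenyl; it stays within the scatter. Taken together, a drop of about the size of the amino step is expected for compound 4, with the change of ring adding little either way. Compound 4 is therefore estimated at 10 nM, with a range from 4 nM to 30 nM. That estimate means a step of a 12-fold lower number from compound 1 to compound 4 (1.08 log units; beyond the scatter) is expected, a lower number and beyond the scatter.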

Compound 4, half-maximal inhibitory concentration: 108 nM
The estimate for compound 4 lay 11-fold (1.03 log units) below the measured number; the whole stated range lies below it.
By their numbers in this assay, from the lowest: compound 2; then compounds 3, 4 and 1 (each within the scatter of the next).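

At this position, the strong result with 2-aminophenyl does not carry over to the ring with a nitrogen atom: in this assay, replacing it with 4-aminopyridin-3-yl gives a 14-fold higher number from compound 2 to compound 4 (1.13 log units; beyond the scatter) and that large step lies beyond the scatter. The other two comparisons, a 1.1-fold lower number from compound 1 to compound 4 (0.05 log units; within the scatter) and a 1.7-fold higher number from compound 3 to compound 4 (0.23 log units; within the scatter), both stay within the scatter, so the new group performs on a par with 2-methylphenyl and 3-methylpyridin-4-yl rather than with 2-aminophenyl. The effect of the amino group therefore depends on the ring that carries it, and the two single changes do not simply add up in compound 4, although nothing shown here bears on the reason for that.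

3-methylpyridin-4-yl and 4-aminopyridin-3-yl are joined to the core through different ring positions. Compound 3 and compound 4 do not give a clean swap of methyl for amino on an otherwise identical ring. Still open, from the compounds shown here alone, is how this position would respond to a 2-aminopyridin-3-yl ring, or to a 2-hydroxyphenyl or 2-(methylamino)phenyl group in place of 2-aminophenyl.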